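This account rests on a few compounds, and the source may have more. Where it says the series, first, only, none or still open, it means among the compounds named here.

Compounds measured in a functional assay on WI-38 VA13 cells (Homo sapiens) for cytotoxicity; on this read-out lower numbers stand for an effect already at smaller amounts and higher numbers for an effect only at larger amounts of compound:
compound 1 `COc1ccccc1C(=O)c1sc2nc(-c3cccs3)ccc2c1N` gives 0.059 ug/mL;
compound 2 `COc1ccc(C(=O)c2sc3nc(-c4cccs4)ccc3c2N)cc1` gives 0.77 ug/mL;
compound 3 `Nc1c(C(=O)c2cccc(F)c2)sc2nc(-c3cccs3)ccc12` gives 0.025 ug/mL.

Compound 1 holds the second highest number of the three in this assay. Its nearest neighbour is compound 3, reached by a 2.4-fold lower number from compound 1 to compound 3 (0.37 log units; beyond the scatter); its furthest is compound 2, reached by a 13-fold higher number from compound 1 to compound 2 (1.12 log units; beyond the scatter). The step that separates compound 2 from compound 3 is a 31-fold lower number from compound 2 to compound 3 (1.49 log units; beyond the scatter).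

Compound 4 `Nc1c(C(=O)c2ccc(F)cc2)sc2nc(-c3cccs3)ccc12` is the compound not yet measured. It differs from compound 1 in one place: 4-fluorophenyl in place of 2-methoxyphenyl on a carbonyl carbon. Among the compounds with values here, two measured steps bear on this change. The step from compound 1 to compound 2 shows what happens when a methoxy group is moved from the 2-position to the 4-position of that phenyl ring, and it was large. The step from compound 1 to compound 3 shows a fluorine in the 3-position in place of the 2-methoxy group, and it was modest in the opposite direction. Compound 4 combines a fluorine with the 4-position, so neither step matches it exactly. The expectation for compound 4 is a number above that of compound 1, less far than compound 2, a step of a 2.5-fold higher number from compound 1 to compound 4 (0.41 log units; beyond the scatter). Compound 4 is therefore estimated at 0.15 ug/mL, with a range from 0.03 ug/mL to 0.8 ug/mL.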

Compound 4, half-maximal effective concentration: 1.8 ug/mL
Compound 4: middle estimate off by 12-fold (1.08 log units), on the low side; measured number above the stated range.
By their numbers in this assay, from the lowest: compound 3; then compound 1; then compound 2; then compound 4.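

In this assay the change to 4-fluorophenyl on the carbonyl carbon gives a large rise in the number (a 31-fold higher number from compound 1 to compound 4 (1.48 log units; beyond the scatter)), so a fluorophenyl group here does not by itself keep the number low, as compound 3 alone might have suggested. The place of the fluorine on the ring matters greatly, since going from 3-fluorophenyl to 4-fluorophenyl gives the largest step among these four compounds (a 72-fold higher number from compound 3 to compound 4 (1.86 log units; beyond the scatter)), whereas fluoro in place of methoxy on the same ring carbon gives only a modest step (a 2.3-fold higher number from compound 2 to compound 4 (0.37 log units; beyond the scatter)). Compound 2 and compound 4, the 4-methoxyphenyl and 4-fluorophenyl compounds, hold the two highest numbers of the four with no compound going against this, but nothing available explains the pattern.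

The compounds shown leave open whether 4-chlorophenyl or 4-aminophenyl on the carbonyl carbon would also give a high number, and whether this pattern extends beyond a methoxy group and a fluorine. They also leave open where 2-fluorophenyl, 3-methoxyphenyl and plain phenyl would fall, so the separate contributions of the group and its place on the ring remain only partly resolved.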